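Series notes: lipophilicity of a positional isomer, compound 4

This account rests on a few compounds, and the source may have more. Where it says the series, first, only, none or still open, it means among the compounds named here.

Values in a physicochemical assay for lipophilicity (a lower number here means a more polar compound, a higher number a more lipophilic compound), measured so far:
compound 1 `CCCOc1ccc2[nH]c(-c3ccc(OC)cc3)c(C3=C(Br)C(=O)NC3=O)c2c1` gives 3.12
compound 2 `O=C(CCCCCc1[nH]c2ccccc2c1C1=C(Br)C(=O)NC1=O)Nc1ccccc1` gives 2.68
compound 3 `Cc1ccc(NC(=O)CCCc2[nH]c3ccccc3c2C2=C(Br)C(=O)NC2=O)cc1` gives 2.56

Compound 3 sits at the lower end of these three numbers. Compound 2 lies within the usual scatter of it, so no order between the two can be read; compound 1 lies beyond the scatter, higher. Compound 4 `Cc1ccccc1NC(=O)CCCc1[nH]c2ccccc2c1C1=C(Br)C(=O)NC1=O` has not yet been measured in this assay. It differs from compound 3 in one place: 2-methylphenyl in place of 4-methylphenyl on an amide-type nitrogen, the two having the same atoms joined differently. Among the measured compounds shown here, no pair of measured compounds shares a change of this kind, so no measured step can anchor the expectation. With the leaving and entering groups so alike, the expected step in this assay is a number 0.06 log units lower from compound 3 to compound 4 (within the scatter), none beyond the scatter in either direction. For compound 4 the estimated value in this assay is 2.5, with a range from 2.15 to 2.9; a limit rather than a number is not expected.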

Compound 4, partition coefficient: 2.56
Compound 4: middle estimate off by 0.06 log units, on the low side; measured number inside the range.
By their numbers in this assay, from the lowest: compounds 3, 4 and 2 (each within the scatter of the next); then compound 1.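

In this assay, 2-methylphenyl in place of 4-methylphenyl on an amide-type nitrogen gives no change at the digits printed from compound 3 to compound 4 (within the scatter). Among the compounds shown here, compounds 1 to 3 contained no pair differing in one place, so this is the only step that can be read directly, and it shows no measurable dependence on where the methyl sits in this pair. Nothing available explains this result.

From the compounds shown here alone, whether a different group, such as a carboxylic acid or an amine in place of the methyl, would give a step beyond the scatter remains open, since this change keeps the same atoms. Going by these compounds, it is also open whether the same exchange would read alike on a longer chain between the amide and the shared core.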